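Methylating the sulfonamide nitrogen of compound 3

The compounds below may be only part of what the source reports. "The series", "measured", "known", "first", "only" and "open" are said of these compounds alone.

This study follows compound 3, `CC(=O)N1CCC[C@H](NS(C)(=O)=O)[C@@H]1CO[C@H]1CC[C@@H](C(C)C)CC1`, which in a functional assay on CHO-K1 cells for agonist activity at Orexin receptor type 2 (Homo sapiens), read by FLIPR and calcium flux (a higher number here means that more compound is needed for the effect, a lower number that less compound is needed), gives 330 nM. For the measured compounds named here, compound 3 holds the only number in the set. Compound 1, `CCS(=O)(=O)N[C@@H]1CCCN(C(C)=O)[C@H]1CO[C@H]1CC[C@@H](C(C)C)CC1`, reaches only the limit of this assay, > 30000 nM. Compound 2, `CCS(=O)(=O)N[C@@H]1CCCN(C(C)=O)[C@H]1CO[C@H]1CC[C@H](C(C)C)CC1`, likewise stops at the limit, > 30000 nM. Going by the values given here, the single measured step, a step that the two limits leave unreadable from compound 1 to compound 2, is unreadable because of the limit of > 30000 nM in this assay, at which 2 of the 3 values shown sit; it concerns only configuration because of the fact that compounds 1 and 2 differ only in the configuration as drawn, so it says nothing about the sulfonamide nitrogen. The new compound 4, `CC(=O)N1CCC[C@H](N(C)S(C)(=O)=O)[C@@H]1CO[C@H]1CC[C@@H](C(C)C)CC1`, differs from compound 3 by methyl in place of hydrogen on a sulfonamide nitrogen. Among the compounds with values here, no measured step bears on this change, and the set offers no pair that touches that nitrogen. Without such a precedent, the account leans toward expecting a loss, with wide uncertainty: compound 4 is estimated at 3000 nM in this assay, between 400 nM and 30000 nM. That estimate means an expected weakening step a 9.1-fold higher number from compound 3 to compound 4 (0.96 log units; beyond the scatter), and a fair chance that compound 4 reaches only the limit.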

Compound 4, half-maximal effective concentration: > 30000 nM
Compound 4 was reported as a limit; the forecaster's own chance of this, stated with the estimate: 30%; at least 10-fold (1.00 log units) between middle value and limit.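

In this assay, the sulfonamide nitrogen of compound 3 turns out to be sensitive to even the smallest substitution: methyl in place of hydrogen there gives an at least 90-fold higher number from compound 3 to compound 4 (1.95 log units; beyond the scatter). For the compounds shown here, this is the first measured step at this nitrogen, since the only earlier pair differed in configuration alone and could say nothing about it. Compound 4 gives > 30000 nM, which is a limit of the assay, so the step marks only a minimum and its full size remains unknown: the limit of > 30000 nM in this assay, at which 3 of the 4 values shown sit.

On these data alone, whether any group other than hydrogen can be carried on this nitrogen stays open, for instance a longer chain, a hydroxyethyl group or a carboxylic acid. Going by these compounds alone, the one step among the earlier compounds also still cannot be read, so the role of configuration remains unsettled.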